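A few compounds are considered here, and "the series" means these few. Any claim that something is new, unique, unknown or untested is made for them only; others in the source may bear on it.

In a functional assay, read by spectrophotometry, tested at 100 uM (on this read-out higher numbers stand for weaker inhibition and lower numbers for stronger inhibition), three compounds with a shared core have been measured so far. Compound 1 `O=C(/C=C/c1ccc(F)cc1)c1cccc(NC(=O)c2cc(-c3ccncc3)n[nH]2)c1` gives 58700 nM while compound 2 `COc1ccc(/C=C/C(=O)c2cccc(NC(=O)c3cc(-c4ccncc4)n[nH]3)c2)cc1` gives 54600 nM and compound 3 `O=C(/C=C/c1ccccc1Cl)c1cccc(NC(=O)c2cc(-c3ccncc3)n[nH]2)c1` gives 79800 nM on the same read-out. Compound 1 stands with the other two and not apart from them, since these numbers all lie within the scatter of one another and cannot be ranked.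

Compound 4 `COc1cc(/C=C/C(=O)c2cccc(NC(=O)c3cc(-c4ccncc4)n[nH]3)c2)cc(OC)c1OC` differs from compound 1 by one change 3,4,5-trimethoxyphenyl in place of 4-fluorophenyl on a double-bonded chain carbon bound to a double-bonded chain carbon on a double-bonded chain carbon bound to a double-bonded chain carbon. All three measured steps replace the aryl group at that same place. They are a 1.1-fold lower number from compound 1 to compound 2 (0.03 log units; within the scatter) and a 1.4-fold higher number from compound 1 to compound 3 (0.13 log units; within the scatter) and a 1.5-fold higher number from compound 2 to compound 3 (0.16 log units; within the scatter) in turn, and each stays within the scatter. Among the measured compounds shown here, the nearest precedent is compound 2, where methoxy in place of fluoro gave a 1.1-fold lower number from compound 1 to compound 2 (0.03 log units; within the scatter) as its whole effect. For the measured compounds named here, no measured compound carries the 3,4,5-trimethoxyphenyl group, so the expectation reaches past the data and the range is kept wide. No shift beyond the scatter is expected in this assay from this change. The expected step is a 1.0-fold higher number from compound 1 to compound 4 (0.01 log units; within the scatter) on this reasoning. Compound 4 is therefore expected at 60000 nM and the estimated range runs from 30000 nM up to 100000 nM as the likely span.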

Compound 4, half-maximal inhibitory concentration: 52900 nM
For compound 4 the middle estimate is 1.1-fold (0.05 log units) above the measured one, and the stated range covers the measured number.
By their numbers in this assay, from the lowest: compounds 4, 2, 1 and 3 (each within the scatter of the next).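

In this assay, the 3,4,5-trimethoxyphenyl group, with 12 heavy atoms and 3 hydrogen-bond acceptors against 7 heavy atoms and 0 acceptors in the 4-fluorophenyl group, gives a 1.1-fold lower number from compound 1 to compound 4 (0.05 log units; within the scatter) and, against the other two aryl groups, a 1.0-fold lower number from compound 2 to compound 4 (0.01 log units; within the scatter) and a 1.5-fold lower number from compound 3 to compound 4 (0.18 log units; within the scatter). The earlier compounds shown here carried one substituent on the phenyl ring, whereas compound 4 shows that three methoxy groups on that ring, on a double-bonded chain carbon bound to a double-bonded chain carbon, also give no step beyond the scatter, so all four compounds still cannot be ranked. The data at hand offer nothing that would account for this flat picture.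

As far as these compounds go, all four compounds keep a substituted phenyl ring at this place, so it remains open whether a basic amine, a carboxylic acid or a saturated alkyl chain there would give a step beyond the scatter. From the compounds shown here alone, it also remains open whether a change elsewhere on the shared core would move the number more than any change at this place has.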